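Benzyl on the ring nitrogen of the compound 3 scaffold

The compounds below may be only part of what the source reports. "The series", "measured", "known", "first", "only" and "open" are said of these compounds alone.

Compounds measured so far:
- compound 1, `CCC(=O)NCC1CCc2ccccc2N1CC(=O)NC`: in a functional assay on CHO cells with melatonin receptor type 1A (Homo sapiens) as the target, read by GTPgammaS binding, with a stated time of 1 h (a lower number here means that less compound is needed, a higher number that more compound is needed for the effect), compound 1 is reported as "not determined" (no result reported)
- compound 2, `O=C(NCC1CCc2ccccc2N1Cc1ccccc1)C1CCC1`: in this assay compound 2 is reported as "not determined" (no result reported)
- compound 3, `CCC(=O)NCC1CCc2ccccc2N1`: 242 nM

Among the compounds with values here, compound 3 carries the only number in the set; compounds 1 and 2 appear without any value, so no step between measured compounds can be read. Compound 3 therefore stands alone as the sole reference point.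

Compound 4, `CCC(=O)NCC1CCc2ccccc2N1Cc1ccccc1`, differs from compound 3 in one place: benzyl in place of hydrogen on a nitrogen on an aromatic ring in a ring. The change is an addition of a benzyl group, nothing leaves but a hydrogen. Within the data shown here, no measured pair shows what such an addition does in this assay, so the direction is not anchored by data.

For compound 4 the step of a 1.3-fold lower number from compound 3 to compound 4 (0.13 log units; within the scatter) is expected to be modest, not clearly beyond the scatter, with the direction left open. Compound 4 is estimated at 180 nM, within a range of 30 nM to 1200 nM, resting solely on compound 3 at 242 nM as the anchor.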

Compound 4, half-maximal effective concentration: 36 nM
The estimate for compound 4 lay 5.0-fold (0.70 log units) above the measured number; measured number inside the range.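

In this assay, a 6.7-fold lower number from compound 3 to compound 4 (0.83 log units; beyond the scatter) gives the series its first readable step: benzyl in place of hydrogen on a nitrogen on an aromatic ring in a ring lowers the number, with the (propanoylamino)methyl group held constant. This position therefore accepts a group of this size, with one six-membered aromatic ring of carbon only, without any loss in this read-out. No supporting data bear on the origin of the step.

Steps involving compound 1 or compound 2 cannot be read, so the benzyl result has no second comparison at this position. On these data alone, it remains open whether the aromatic ring itself matters, which a plain methyl or a cyclohexylmethyl group would test, and whether a longer chain such as phenethyl or a benzyl ring bearing an amine would follow the same direction.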